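The source may report more compounds than this note shows. Statements on the series, on what has been measured and on what is new or still open speak of the compounds shown alone.

Measured compounds:
Compound 1: `COc1ccccc1CC1(OC)CCN(c2ccc(C(=O)NS(=O)(=O)c3ccc(N[C@H](CCN(C)C)CSc4ccccc4)c([N+](=O)[O-])c3)cc2)CC1` — 250 nM
Compound 2: `COC1(Cc2ccccc2-c2ccccc2)CCN(c2ccc(C(=O)NS(=O)(=O)c3ccc(N[C@H](CCN(C)C)CSc4ccccc4)c([N+](=O)[O-])c3)cc2)CC1` — 20 nM
Compound 3: `CN(C)CC[C@H](CSc1ccccc1)Nc1ccc(S(=O)(=O)NC(=O)c2ccc(N3CCC(=Cc4ccc(F)cc4)CC3)cc2)cc1[N+](=O)[O-]` — 600 nM

In a functional assay (FL5.12 cells, Mus musculus) with Apoptosis regulator Bcl-2 (Homo sapiens) as the target (a lower number here means that less compound is needed, a higher number that more compound is needed for the effect), compound 3 gives 600 nM, the highest of the three numbers. Compound 1 comes nearest with 250 nM, and compound 2 lies furthest away with 20 nM; both gaps are beyond the scatter, so compound 3 is the weakest of the measured set in this assay.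

Compound 4 is `CN(C)CC[C@H](CSc1ccccc1)Nc1ccc(S(=O)(=O)NC(=O)c2ccc(N3CCC(=Cc4cccnc4)CC3)cc2)cc1[N+](=O)[O-]`. It differs from compound 3 in one place: pyridin-3-yl in place of 4-fluorophenyl on a double-bonded chain carbon bound to a double-bonded ring carbon.

Among the compounds with values here, the only measured step is a 13-fold lower number from compound 1 to compound 2 (1.10 log units; beyond the scatter), in which a phenyl replaces a methoxy on an aromatic carbon of the core of compound 1. That step sits at a different place and is of a different kind from the change made here, so it gives no direct guide. Within the data shown here, no measured pair exchanges a fluorophenyl for a pyridyl anywhere in this set.

With nothing that bears directly on the change, the step from compound 3 to compound 4 is expected to be no change at the digits printed from compound 3 to compound 4 (within the scatter), that is, no change beyond the scatter. Compound 4 is therefore estimated at 600 nM in this assay, with a range from 200 nM to 1800 nM.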

Compound 4, half-maximal effective concentration: 5300 nM
Compound 4: the middle estimate sits 8.8-fold (0.95 log units) below what was measured; the whole stated range lies below it.
By their numbers in this assay, from the lowest: compound 2; then compound 1; then compound 3; then compound 4.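

The position on a double-bonded chain carbon bound to a double-bonded ring carbon proves sensitive to a single exchange of one six-membered aromatic ring for another: in this assay, pyridin-3-yl in place of 4-fluorophenyl brings an 8.8-fold higher number from compound 3 to compound 4 (0.95 log units; beyond the scatter) and leaves compound 4 with the highest number of the four compounds. The earlier step, a 13-fold lower number from compound 1 to compound 2 (1.10 log units; beyond the scatter) in the same assay, lay at a different place and involved a different kind of change, so it said nothing about this position, and the new step runs the other way, towards a higher number. Nothing measured here accounts for the rise.

The exchange removes the fluorine and brings in the ring nitrogen in one move, so the compounds shown leave open how much of the step belongs to each, a question that a plain phenyl on the same carbon would address. They also leave open whether the position of the ring nitrogen matters, as pyridin-2-yl or pyridin-4-yl would show, and whether the same exchange would carry the same size of step on another part of the series.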